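The source may report more compounds than this note shows. Statements on the series, on what has been measured and on what is new or still open speak of the compounds shown alone.

Compound 1, with structure `C/N=C(/NC#N)NCCCn1nc(-c2ccccc2)ccc1=O`, was tested in a functional assay on the whole organism (stomach) with Rattus norvegicus as the target; on this read-out lower numbers stand for an effect already at smaller amounts and higher numbers for an effect only at larger amounts of compound. In this assay compound 1 gives > 100 mg/kg, which is a limit of the assay and not a number. Compound 2, with structure `C/N=C(/NC#N)NCCCCn1nc(-c2ccc(Cl)cc2)ccc1=O`, gives 100 mg/kg in this assay. Among the measured compounds shown here, compound 1 and compound 2 differ in more than one place, so no single step connects them; their two values show only that both sit at the high end of the dose range covered. Where compound 1 stands is set by the limit of > 100 mg/kg in this assay, at which 1 of the 2 values shown sits.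

Compound 3, with structure `C/N=C(\S)NCCCn1nc(-c2ccccc2)ccc1=O`, has not yet been measured. It differs from compound 1 at one place: a group of 4 heavy atoms (2 carbon, 1 nitrogen, 1 sulfur; no ring) in place of a group of 6 heavy atoms (3 carbon, 3 nitrogen; no ring), on an amine nitrogen. No comparable change appears among the measured compounds, so the effect of this change in this assay is not anchored by any measured step. The step of a number no higher from compound 1 to compound 3 (the limit leaves the size open) that the estimate means is expected to be none beyond the usual scatter. In this assay compound 3 is estimated at 100 mg/kg, within a range from 30 mg/kg to 300 mg/kg.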

Compound 3, dose for half-maximal effect: > 100 mg/kg
Compound 3: a limit, no number; the forecaster's own chance of this, stated with the estimate: 50%; the middle value lies on the limit itself.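

In this assay, among the compounds shown here, compound 1 and compound 3 both rest on a limit of the assay and not on a number, so no step between them can be read: the limit of > 100 mg/kg in this assay, at which 2 of the 3 values shown sit.

The compounds shown leave open whether the group of 4 heavy atoms in place of the group of 6 heavy atoms changes the effect at all, and in which direction.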